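Moving from a dihydroxyphenyl to an aminophenyl group

The source may report more compounds than this note shows. Statements on the series, on what has been measured and on what is new or still open speak of the compounds shown alone.

Compound 1 `COc1cc(-c2cc(-c3cccc(O)c3)nc(-c3ccccc3)n2)cc(OC)c1OC` gives 1990 nM
Compound 2 `COc1cc(-c2cc(-c3ccc(O)cc3O)nc(-c3ccccc3)n2)cc(OC)c1OC` gives 810 nM

Among the measured compounds shown here, in a functional assay on MDA-MB-231 cells (Homo sapiens) for inhibition, read by MTT assay, with a stated time of 48 h (on this read-out lower numbers stand for stronger inhibition and higher numbers for weaker inhibition), compound 2 holds the lower of the two numbers so far (810 nM). Compound 3 `COc1cc(-c2cc(-c3ccc(N)cc3)nc(-c3ccccc3)n2)cc(OC)c1OC` keeps the shared core and carries 4-aminophenyl in place of 2,4-dihydroxyphenyl (4-aminophenyl in place of 2,4-dihydroxyphenyl on an aromatic carbon). For the measured compounds named here, only one measured step changes this same place, swapping 3-hydroxyphenyl for 2,4-dihydroxyphenyl (a 2.5-fold lower number from compound 1 to compound 2 (0.39 log units; beyond the scatter)). That step is modest, and neither compound carries an amino group, so it offers only a rough guide to size. Compound 2 is the lower of just two compounds, so a modest move towards a higher number seems more likely than a further drop, though the direction remains uncertain. The expected change is small (a 1.6-fold higher number from compound 2 to compound 3 (0.21 log units; within the scatter)). For compound 3 the estimated value is 1300 nM, with an expected range from 350 nM to 5000 nM.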

Compound 3, half-maximal inhibitory concentration: 1010 nM
The estimate for compound 3 lay 1.3-fold (0.11 log units) above the measured number, within the range that was stated.
By their numbers in this assay, from the lowest: compounds 2, 3 and 1 (each within the scatter of the next, the first and the last beyond it).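

In this assay this position tolerates a ring that carries an amino group and no hydroxyl: 4-aminophenyl in place of 2,4-dihydroxyphenyl gives a 1.2-fold higher number from compound 2 to compound 3 (0.10 log units; within the scatter), and 4-aminophenyl in place of 3-hydroxyphenyl gives a 2.0-fold lower number from compound 1 to compound 3 (0.29 log units; within the scatter). Compound 3 thus lies within the scatter of both compound 1 and compound 2, although those two lie beyond the scatter of each other, so among these three compounds a hydroxyl on this ring is not needed for a number of this size. Nothing measured here offers a reason for these numbers. The compounds shown leave open what a bare phenyl group would give at this position, so the amino group's own contribution remains unknown. They also leave open how a methoxy group, a carboxylic acid or a longer amine chain on this ring would read.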